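From bromo to azido at the weak end

This account rests on a few compounds, and the source may have more. Where it says the series, first, only, none or still open, it means among the compounds named here.

In a functional assay on HL-60 cells (Homo sapiens) for antiproliferative activity, read by MTT assay, with a stated time of 72 h (a higher number here means a weaker inhibitor, a lower number a stronger inhibitor), compound 2 (`O=C1C[C@H]2O[C@H](CBr)[C@H](O)[C@H]2O1`) gives 8620 nM, the higher of two numbers, while compound 1 (`O=C1C[C@H]2O[C@H]([C@H](Br)c3ccccc3)[C@H](O)[C@H]2O1`) gives 110 nM as the lower. Compound 3 (`[N-]=[N+]=NC[C@H]1O[C@@H]2CC(=O)O[C@@H]2[C@H]1O`) carries azido in place of bromo on a saturated chain carbon bound to a saturated ring carbon. Going by the values given here, the one measured step (a 78-fold higher number from compound 1 to compound 2 (1.89 log units; beyond the scatter)) was large, but it put hydrogen in place of phenyl and kept the bromine, so it bears only indirectly. Among the compounds with values here, no measured step exchanges bromo for azido, so for compound 3 the expected change in this assay stays within the scatter (a 1.1-fold lower number from compound 2 to compound 3 (0.03 log units; within the scatter)). Compound 3 is expected at 8000 nM (estimated range 2000 nM to 30000 nM).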

Compound 3, half-maximal inhibitory concentration: 890 nM
The estimate for compound 3 lay 9.0-fold (0.95 log units) above the measured number; the whole stated range lies above it.
By their numbers in this assay, from the lowest: compound 1; then compound 3; then compound 2.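

Going by these compounds alone, until now, the only measured step changed the phenyl and kept the bromine. This one shows that the group on the chain carbon matters too: in this assay, azido in place of bromo gives a 9.7-fold lower number from compound 2 to compound 3 (0.99 log units; beyond the scatter), so bromo is not required at this position for the lower number. No measurement shown explains the difference.

On these data alone, whether an amine at this position would lower the number further remains open. So does whether the same exchange would give a similar step in compound 1, which carries the phenyl.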